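A few compounds are considered here, and "the series" means these few. Any claim that something is new, unique, unknown or untested is made for them only; others in the source may bear on it.

In an ADME assay on S9 fraction from liver (Rattus norvegicus) for metabolic stability, read by LC-MS, using NADPH, with a stated time of 60 min, tested at 10 uM (a higher number here means that more of the compound is left, a lower number that less of the compound is left), compound 1 (`N#CC1(c2cc(CCO)cc(-c3ccnc4[nH]nc(C(F)(F)F)c34)c2)CC1`) gives 17%, compound 2 (`C[C@@H](O)Cc1cc(-c2ccnc3[nH]nc(C(F)(F)F)c23)cc(C2(C#N)CC2)c1`) gives 42% and compound 3 (`CC(C)C(O)Cc1cc(-c2ccnc3[nH]nc(C(F)(F)F)c23)cc(C2(C#N)CC2)c1`) gives 19%. Compound 3 thus lies within the scatter of compound 1 and clearly under compound 2. Compound 4 (`N#CC1(c2cc(CC(O)C(F)(F)F)cc(-c3ccnc4[nH]nc(C(F)(F)F)c34)c2)CC1`) differs from compound 3 by trifluoromethyl in place of isopropyl on a saturated chain carbon bound to an oxygen on a saturated carbon and a saturated chain carbon, with trifluoromethyl in place of isopropyl on a saturated chain carbon bound to an oxygen on a saturated carbon and a saturated chain carbon. Within the data shown here, three measured steps touch this place: the modest rise a number 25 percentage points higher from compound 1 to compound 2 (beyond the scatter), the step within the scatter a number 2 percentage points higher from compound 1 to compound 3 (within the scatter) and the modest fall a number 23 percentage points lower from compound 2 to compound 3 (beyond the scatter). None carries trifluoromethyl, so the expectation is loose. A modest rise is expected, of about the size seen in compound 2, namely a number 19 percentage points higher from compound 3 to compound 4 (beyond the scatter). For compound 4 the estimated value is 38%, with an expected range from 18% to 62%.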

Compound 4, percent of the compound remaining: 71%
The estimate for compound 4 lay 33 percentage points below the measured number; the whole stated range lies below it.
By their numbers in this assay, from the lowest: compounds 1 and 3 (each within the scatter of the next); then compound 2; then compound 4.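

At this place, on a saturated chain carbon bound to an oxygen on a saturated carbon and a saturated chain carbon, trifluoromethyl gives a large rise in this assay, a number 52 percentage points higher from compound 3 to compound 4 (beyond the scatter) and a number 54 percentage points higher from compound 1 to compound 4 (beyond the scatter), whereas isopropyl stayed level with hydrogen. Among these compounds, the gain also goes beyond that of methyl, with a number 29 percentage points higher from compound 2 to compound 4 (beyond the scatter), so this position tolerates far more change in this read-out than the earlier compounds showed. No measurement at hand explains the result. Open, going by these compounds, is whether difluoromethyl or pentafluoroethyl at this place would keep the number, and whether an amine could stand in for the hydroxyl.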